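The source may report more compounds than this note shows. Statements on the series, on what has been measured and on what is new or still open speak of the compounds shown alone.

Measured so far in a functional assay on the whole organism (strain Kunming) with Mus musculus as the target, in the maximal electroshock model; on this read-out higher numbers stand for an effect only at larger amounts of compound and lower numbers for an effect already at smaller amounts:
- compound 1 `O=C(/C=C/c1ccc(F)cc1)NCCO` gives 45.6 mg/kg
- compound 2 `O=C(/C=C/c1ccc(Br)cc1)NCCO` gives 76 mg/kg
- compound 3 `O=C(/C=C/c1ccccc1F)NCCO` gives 35.3 mg/kg

Compound 3 lies within the scatter of compound 1, while compound 2 gives a higher number than compound 3, beyond the scatter. The next change leads to compound 4 `O=C(/C=C/c1ccccc1Cl)NCCO` and is chloro in place of fluoro on an aromatic carbon, with chloro in place of fluoro, ortho to a group of 8 heavy atoms. Among the measured compounds shown here, no chloro compound has been measured. The nearest evidence is a 1.7-fold higher number from compound 1 to compound 2 (0.22 log units; within the scatter), for bromo in place of fluoro, though not at this place. A small rise, within the scatter, is therefore expected, and the estimated step is a 1.2-fold higher number from compound 3 to compound 4 (0.10 log units; within the scatter) in this assay as the short form of the read-out. For compound 4 the expected value is 44 mg/kg, with an estimated range of 24 mg/kg to 80 mg/kg.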

Compound 4, dose for half-maximal effect: 59 mg/kg
Estimate against measurement, compound 4: 1.3-fold (0.13 log units) below, within the range that was stated.
By their numbers in this assay, from the lowest: compounds 3, 1, 4 and 2 (each within the scatter of the next, the first and the last beyond it).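

In this assay, chloro in place of fluoro on an aromatic carbon, ortho to a group of 8 heavy atoms, gives a 1.7-fold higher number from compound 3 to compound 4 (0.22 log units; within the scatter). Among the compounds shown here, this is the first reading of a halogen exchange at this position, and it stays within the scatter, as does a 1.7-fold higher number from compound 1 to compound 2 (0.22 log units; within the scatter) for bromo in place of fluoro elsewhere on the aromatic ring. Nothing measured explains the step.

Bromo at this position remains open. So does whether a methoxy or amino group here would move the number beyond the scatter.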